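Fluoro on the phenyl of compound 1: cytotoxicity outlook

A few compounds are considered here, and "the series" means these few. Any claim that something is new, unique, unknown or untested is made for them only; others in the source may bear on it.

The series is followed in an ADME assay on HepG2 2.2.15 cells (Homo sapiens) for cytotoxicity; on this read-out lower numbers stand for higher toxicity in this test and higher numbers for lower toxicity in this test. Compound 1 `O=c1[nH]c2ccc(Cl)cc2c(-c2ccccc2)c1CCO` reports only a limit there, > 4910000 nM, so no number is known for it; of the three values shown, one further is also a limit, so compound 1 cannot be ranked against the others. Compound 3 `O=c1cc(-c2ccccc2F)c2cc(Cl)ccc2[nH]1` likewise returns only a limit, > 5460000 nM. Within the data shown here, compound 2 `Nc1c(-c2ccccc2Cl)c2cc(Cl)ccc2[nH]c1=O` is the one measured number, at 341000 nM in this assay. Two limits therefore mark the upper reach of the read-out, the limit of > 4910000 nM in this assay, at which 1 of the 3 values shown sits, and (the limit of > 5460000 nM in this assay, at which 1 of the 3 values shown sits).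

Compound 4 `O=c1[nH]c2ccc(Cl)cc2c(-c2ccccc2F)c1CCO` is compound 1 with fluoro in place of hydrogen on an aromatic carbon. Among the measured compounds shown here, no step between measured compounds is available for this change. Since compound 1 sits at a limit in this assay, and compound 3, which carries the same 2-fluorophenyl, also sits at a limit, no step beyond the usual scatter is expected from compound 1 to compound 4, that is a step that the limit leaves unreadable from compound 1 to compound 4. Compound 4 is therefore estimated at 5000000 nM in this assay, within 1500000 nM to 10000000 nM, most likely reported again only as a limit.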

Compound 4, half-maximal cytotoxic concentration: > 2990000 nM
Compound 4 was reported as a limit; the forecaster's own chance of this, stated with the estimate: 75%; the middle value is on the limit's open side.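

Compound 4 is also reported only as a limit, so no step can be read from compound 1 to compound 4 or from compound 3 to compound 4. The compounds shown leave open whether either fluoro or 2-hydroxyethyl in place of hydrogen changes the read-out in this assay.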